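Moving the chlorine on the phenyl group of compound 3

The compounds below may be only part of what the source reports. "The series", "measured", "known", "first", "only" and "open" are said of these compounds alone.

Of the compounds shown here, three sharing one core have been measured in an assay on Sf9 cells for inhibition of serine/threonine-protein kinase 4 (Homo sapiens), read by luminescence and ADP-Glo, with a stated time of 1 h, in the presence of a further agent that is not named here; on this read-out lower numbers stand for stronger inhibition and higher numbers for weaker inhibition. Compound 1, `CC1C(=O)N(C)c2cnc(Nc3ccc(S(N)(=O)=O)cc3)nc2N1C`, gives 313 nM. Compound 2, `CCC1C(=O)N(C)c2cnc(Nc3ccc(S(N)(=O)=O)cc3)nc2N1C`, gives 479 nM, and the step of a 1.5-fold higher number from compound 1 to compound 2 (0.18 log units; within the scatter) lies within the scatter. Compound 3, `CN1C(=O)C(c2cccc(Cl)c2)N(C)c2nc(Nc3ccc(S(N)(=O)=O)cc3)ncc21`, gives 989 nM, the highest of the three numbers; it is the weakest inhibitor here, since the steps of a 2.1-fold higher number from compound 2 to compound 3 (0.31 log units; beyond the scatter) and a 3.2-fold higher number from compound 1 to compound 3 (0.50 log units; beyond the scatter) both lie beyond the scatter.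

Compound 4, `CN1C(=O)C(c2ccccc2Cl)N(C)c2nc(Nc3ccc(S(N)(=O)=O)cc3)ncc21`, is the next to be measured. Its change from compound 3 is 2-chlorophenyl in place of 3-chlorophenyl on a saturated ring carbon: the two compounds contain the same atoms, joined differently. Among the measured compounds shown here, no measured step tests this kind of change. The measured steps only show that a 3-chlorophenyl in place of methyl or ethyl on that ring carbon raised the number by a modest amount, and they say nothing about where the chlorine sits on the phenyl ring. Without a direct guide, the expected step in this assay is none beyond the scatter. Compound 4 is therefore estimated at 1000 nM, with a range from 350 nM to 2800 nM. This estimate corresponds to an expected step of a 1.0-fold higher number from compound 3 to compound 4 (0.00 log units; within the scatter).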

Compound 4, half-maximal inhibitory concentration: 129 nM
Beside the measured number, compound 4's estimate is 7.8-fold (0.89 log units) above it, and the stated range ends above it.
By their numbers in this assay, from the lowest: compound 4; then compounds 1 and 2 (each within the scatter of the next); then compound 3.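

Moving the chlorine within the phenyl group leaves the atoms unchanged, yet it gives a 7.7-fold lower number from compound 3 to compound 4 (0.88 log units; beyond the scatter) in this assay, so the place of the chlorine on that ring clearly matters for this series. Among the compounds shown here, the earlier steps showed only that a 3-chlorophenyl group on this saturated ring carbon gave a higher number than a methyl or ethyl group, whereas the 2-chlorophenyl group reverses that direction, with one step (a 3.7-fold lower number from compound 2 to compound 4 (0.57 log units; beyond the scatter)) against ethyl and another (a 2.4-fold lower number from compound 1 to compound 4 (0.38 log units; beyond the scatter)) against methyl, so a chlorophenyl group here is not tied to weaker inhibition. The compounds offer no measurement that explains the gap between the two chlorophenyl groups.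

The compounds shown leave open how a plain phenyl group with no chlorine would compare, and thus whether the 2-chlorophenyl group improves on the bare ring or the 3-chlorophenyl group falls short of it. They also leave open whether the chlorine itself is needed on the 2-chlorophenyl group, or whether a fluorine, a methyl or a methoxy group in its place would give a similarly low number.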